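The source may report more compounds than this note shows. Statements on the series, on what has been measured and on what is new or still open speak of the compounds shown alone.

Working notes on the series. In a functional assay on NCI-H460 cells (Homo sapiens) for inhibition, read by MTT assay, with a stated time of 24 h, tested at 10 ug/mL (on this read-out higher numbers stand for more inhibition of growth at the one concentration tested and lower numbers for less inhibition of growth), compound 1 (`O=C(CCCCC1CCSS1)Nc1ccc([N+](=O)[O-])c(C(F)(F)F)c1`) gives 12% and compound 2 (`O=C(CCCCC(S)CCS)Nc1cccc(C(F)(F)F)c1`) gives 11.4%. These two values lie within the scatter of each other, so compound 2 is level with compound 1. Compound 3 (`O=C(CCCCC(S)CCS)Nc1ccc([N+](=O)[O-])c(C(F)(F)F)c1`) differs from compound 2 by nitro in place of hydrogen on an aromatic carbon, with nitro in place of hydrogen on an aromatic carbon, ortho to a trifluoromethyl group. For the measured compounds named here, no measured pair isolates this change. Compound 1 also carries nitro and gives 12%, so no step beyond the scatter is expected in this assay. The expected change is a number 1.6 percentage points higher from compound 2 to compound 3 (within the scatter). For compound 3 the estimated value is 13%, within an expected range of 3% to 26%.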

Compound 3, percent growth inhibition at one concentration: 0.97%
Beside the measured number, compound 3's estimate is 12 percentage points above it; the measured number lies below the stated range.
By their numbers in this assay, from the lowest: compound 3; then compounds 2 and 1 (each within the scatter of the next).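

In this assay nitro on this aromatic carbon, ortho to a trifluoromethyl group and para to a large group, gives a number 10.4 percentage points lower from compound 2 to compound 3 (beyond the scatter) on the chain without a ring. With the nitro-bearing aromatic part held constant, the ring-free chain in place of the five-membered ring gives a number 11 percentage points lower from compound 1 to compound 3 (beyond the scatter) and shows that the two chain forms are not interchangeable here. Nothing available explains either step. On these data alone, whether an amine or a nitrile at this position gives a similar step remains open. So does whether a longer chain preserves the gap between the ring and ring-free forms.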